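The source may hold more compounds than are shown below. What is called first, only, known or untested is meant among the compounds shown, and "the series" means these compounds.

Working notes on the series.

Compound 3 `CC(C)CCCSc1nsnc1C1CN2CCCC1C2` carries an isopentyl-type side chain on the shared core with no configuration drawn at its ring stereocentres. In a functional assay on the whole organism with Mus musculus as the target, in the writhing test (on this read-out higher numbers stand for an effect only at larger amounts of compound and lower numbers for an effect already at smaller amounts), compound 3 gives 0.95 mg/kg, the highest of the two numbers measured; its nearest neighbour is compound 1 `FC(F)(F)CCCSc1nsnc1[C@H]1CN2CCC[C@H]1C2`, which in this assay gives 0.1 mg/kg, a gap beyond the scatter. Compound 2 `FC(F)(F)CCCSc1nsnc1[C@@H]1CN2CCC[C@H]1C2` is the diastereomer of compound 1. In this assay compound 2 reaches only a limit, > 10 mg/kg, as recorded in the limit of > 10 mg/kg in this assay, at which 1 of the 3 values shown sits. Among the compounds with values here, the one measured step, an at least 100-fold higher number from compound 1 to compound 2 (2.00 log units; beyond the scatter), thus concerns configuration at a saturated ring carbon, not the side chain.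

Compound 4 `FC(F)(F)CCCSc1nsnc1C1CN2CCCC1C2` is to be measured in this assay. It differs from compound 3 by trifluoromethyl in place of isopropyl on a saturated chain carbon, three bonds along the chain from a sulfur. Within the data shown here, no measured step covers this change directly; the value of compound 1 shows, however, what a trifluoromethyl-terminated chain gives on a stereodefined core, while compound 2 shows that the other configuration contributes only a limit.

Compound 4, drawn without configuration like compound 3, is expected to give 0.3 mg/kg, with a range from 0.1 mg/kg to 1 mg/kg, because compound 1 gives 0.1 mg/kg. The expected step is therefore a lowering, a 3.2-fold lower number from compound 3 to compound 4 (0.50 log units; beyond the scatter), beyond the scatter.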

Compound 4, dose for half-maximal effect: 0.1 mg/kg
Beside the measured number, compound 4's estimate is 3.0-fold (0.48 log units) above it, and the stated range covers the measured number.
By their numbers in this assay, from the lowest: compounds 1 and 4 (each within the scatter of the next); then compound 3. At a limit, above all of these: compound 2.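

With the shared core drawn without configuration in both compounds, this assay now gives a direct reading of trifluoromethyl in place of isopropyl on a saturated chain carbon, three bonds along the chain from a sulfur: a 9.5-fold lower number from compound 3 to compound 4 (0.98 log units; beyond the scatter). On configuration, the step of no change at the digits printed from compound 1 to compound 4 (within the scatter) shows that the drawn stereocentres of compound 1 bring no readable separation from compound 4, a comparison that has to be taken with this reservation: the fact that one of compounds 1 and 4 is drawn with a defined configuration and the other without, at the place where they differ. The step of an at least 100-fold lower number from compound 2 to compound 4 (2.00 log units; beyond the scatter) adds a second large gap on the configuration side, but the value of compound 2 at its one end is a limit and not a number, so the step gives only a minimum size: the limit of > 10 mg/kg in this assay, at which 1 of the 4 values shown sits.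

The compounds shown leave open whether the change from isopropyl to trifluoromethyl reads the same on the stereodefined core of compound 1, and which configurations are present in compound 4. They also leave open how a nitrile, a carboxylic acid or a longer chain at the same chain end would read in this assay.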